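Benzamidomethyl in place of 4-bromophenyl on the shared core

The source may report more compounds than this note shows. Statements on the series, on what has been measured and on what is new or still open speak of the compounds shown alone.

Within the data shown here, in a functional assay on HepG2 cells (Homo sapiens) for inhibition, read by MTT assay, with a stated time of 72 h (on this read-out lower numbers stand for stronger inhibition and higher numbers for weaker inhibition), compound 1 (`O=C(NCc1nnc(SCCCN2CCN(c3nc4ccccc4o3)CC2)o1)c1ccccc1`) gives 88900 nM and compound 2 (`Brc1ccc(-c2nnc(SCCCN3CCN(c4nc5ccccc5s4)CC3)o2)cc1`) gives 103000 nM as the only two numbers so far. These values lie within the scatter of each other, so neither compound stands apart. Compound 3 (`O=C(NCc1nnc(SCCCN2CCN(c3nc4ccccc4s3)CC2)o1)c1ccccc1`) carries benzamidomethyl in place of 4-bromophenyl on an aromatic carbon. Among the measured compounds shown here, no measured step isolates this change, and the expectation rests only on the values of compound 1 and compound 2. The estimated step (a 1.1-fold lower number from compound 2 to compound 3 (0.06 log units; within the scatter)) is expected to stay within the scatter. Compound 3 is estimated at 90000 nM (range 40000 nM to 180000 nM).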

Compound 3, half-maximal inhibitory concentration: 325000 nM
Compound 3: middle estimate off by 3.6-fold (0.56 log units), on the low side; measured number above the stated range.
By their numbers in this assay, from the lowest: compounds 1 and 2 (each within the scatter of the next); then compound 3.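

In this assay, among these compounds, benzamidomethyl in place of 4-bromophenyl on an aromatic carbon gives a 3.2-fold higher number from compound 2 to compound 3 (0.50 log units; beyond the scatter) and thus weaker inhibition, the first change at this position read beyond the scatter. With benzamidomethyl held fixed, 1,3-benzothiazol-2-yl in place of 1,3-benzoxazol-2-yl on an amine nitrogen in a ring gives a 3.7-fold higher number from compound 1 to compound 3 (0.56 log units; beyond the scatter) and so also weakens inhibition. Nothing available explains either step.

Open, on these data alone, is whether an amine or a carboxylic acid on this aromatic carbon would give a lower number. Also open, as far as these compounds go, is whether the 1,3-benzoxazol-2-yl step holds with 4-bromophenyl on the core.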